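From 4-Chlorophenyl to 3,4,5-Trimethoxyphenyl: A Growth Inhibition Estimate

The compounds below may be only part of what the source reports. "The series", "measured", "known", "first", "only" and "open" are said of these compounds alone.

In a functional assay on BT-549 cells (Homo sapiens) for inhibition (a higher number here means a weaker inhibitor of growth, a lower number a stronger inhibitor of growth), compound 1 `COc1cc(/C=C/C(=O)c2cccc(-n3cc(-c4ccc(Cl)cc4)[nH]c3=O)c2)cc(OC)c1OC` gives 12300 nM as its number. Compound 3 `O=C(/C=C/c1cccc(O)c1)c1cccc(-n2cc(-c3ccccc3)[nH]c2=O)c1` gives 9320 nM within the scatter of compound 1, so these two cannot be ranked. Compound 2 `COc1cc(/C=C/C(=O)c2cccc(-n3cc(-c4ccccc4)[nH]c3=O)c2)ccc1O` gives 2780 nM and is clearly lower than either of them.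

Compound 4 `COc1cc(/C=C/C(=O)c2cccc(-n3cc(-c4cc(OC)c(OC)c(OC)c4)[nH]c3=O)c2)cc(OC)c1OC` has not yet been measured. It differs from compound 1 by 3,4,5-trimethoxyphenyl in place of 4-chlorophenyl on an aromatic carbon on an aromatic carbon of a five-membered aromatic ring with 2 nitrogen.

Among the measured compounds shown here, the only measured step of a 3.4-fold higher number from compound 2 to compound 3 (0.53 log units; beyond the scatter) is modest and lies beyond the scatter. It replaces 4-hydroxy-3-methoxyphenyl with 3-hydroxyphenyl, a different group from the one changing here, so it warns that one swap can matter but gives no direction for this one. No step beyond the scatter is therefore expected. The estimate means a 1.2-fold lower number from compound 1 to compound 4 (0.09 log units; within the scatter) in this assay and is expected to stay within the scatter. Compound 4 is estimated at 10000 nM with a range of 3000 nM to 30000 nM around that expected value.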

Compound 4, concentration for 50% growth inhibition: 1520 nM
Compound 4: the middle estimate sits 6.6-fold (0.82 log units) above what was measured; measured number below the stated range.
By their numbers in this assay, from the lowest: compounds 4 and 2 (each within the scatter of the next); then compounds 3 and 1 (each within the scatter of the next).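

On an aromatic carbon of a five-membered aromatic ring with 2 nitrogen, replacing 4-chlorophenyl with 3,4,5-trimethoxyphenyl makes a clear difference in this assay, with an 8.1-fold lower number from compound 1 to compound 4 (0.91 log units; beyond the scatter). Among the compounds shown here, the only earlier step, a 3.4-fold higher number from compound 2 to compound 3 (0.53 log units; beyond the scatter), changed a different group, so this is the first sign that the position carrying the 4-chlorophenyl also matters for growth inhibition. No measurement shown here explains the size or direction of this new step.

This single swap removes the chlorine and adds the methoxy groups at once, so it cannot show how each change contributes. Going by these compounds, how a 4-methoxyphenyl, a 4-aminophenyl or a phenyl ring bearing a carboxylic acid would behave at this position remains open.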